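Cyclopentyl in place of isobutyl on an amide-type nitrogen

A few compounds are considered here, and "the series" means these few. Any claim that something is new, unique, unknown or untested is made for them only; others in the source may bear on it.

In a functional assay on NCI-H1975 cells (Homo sapiens) for antiproliferative activity, read by CCK-8 assay, with a stated time of 72 h (a lower number here means a stronger inhibitor of growth, a higher number a weaker inhibitor of growth), compound 1 `CCC1C(=O)N(C)c2cnc(-n3ccc4cc(C(=O)NC)ccc43)nc2N1c1ccn(C)n1` gives 35700 nM and compound 3 `CCC1C(=O)N(C)c2cnc(-n3ccc4cc(C(=O)NCC(C)C)ccc43)nc2N1c1ccn(C)n1` gives 10200 nM. Compound 2 `CCNC(=O)c1ccc2c(ccn2-c2ncc3c(n2)N(c2ccn(C)n2)C(CC)C(=O)N3C)c1` is recorded as "not active" (no number reported), with no number reported. Within the data shown here, compound 3 therefore holds the lower of the only two numbers.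

Compound 4 `CCC1C(=O)N(C)c2cnc(-n3ccc4cc(C(=O)NC5CCCC5)ccc43)nc2N1c1ccn(C)n1` is the next to be read. The change is cyclopentyl in place of isobutyl on an amide-type nitrogen. Among the measured compounds shown here, only one measured step bears on this change, a 3.5-fold lower number from compound 1 to compound 3 (0.54 log units; beyond the scatter), which is modest and also involves the group on that nitrogen. For the measured compounds named here, no measured compound carries a ring there, so this single step gives only a rough guide to size. Compound 2 has no number and cannot be placed on any trend with group size. With so little evidence, no step beyond the scatter is expected in this assay, although a somewhat lower number would not be surprising. The expected step is a 1.3-fold lower number from compound 3 to compound 4 (0.11 log units; within the scatter). Compound 4 is estimated at 8000 nM, with an expected range of 2500 nM to 30000 nM.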

Compound 4, concentration for 50% growth inhibition: "not active" (no number reported)
Compound 4 has no reported number here; no gap can be computed for the estimate.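

In this assay, among these compounds, compound 4 is recorded as "not active" without a number, as compound 2 is, so no step from compound 3 to compound 4 can be read. Nothing measured here accounts for this result. The compounds shown leave open how cyclopentyl on the amide-type nitrogen compares numerically with isobutyl.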